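Cytotoxicity notes on the carbonyl substituent

The source may report more compounds than this note shows. Statements on the series, on what has been measured and on what is new or still open speak of the compounds shown alone.

Measured in an ADME assay on NIH3T3 cells (Mus musculus) for cytotoxicity, read by fluorescence, with a stated time of 48 h; a higher number here means a weaker inhibitor, a lower number a stronger inhibitor:
- compound 1 `CC(C)C(=O)N1CCN(c2ccnc3cc(Cl)ccc23)CC1`: 21000 nM
- compound 2 `O=C(C1CCCC1)N1CCN(c2ccnc3cc(Cl)ccc23)CC1`: 21000 nM

Unmeasured: compound 3 `O=C(Nc1ccc(Cl)cc1)N1CCN(c2ccnc3cc(Cl)ccc23)CC1`

Level with compound 1 stands compound 2 at 21000 nM. The next change is (4-chlorophenyl)amino in place of cyclopentyl on a carbonyl carbon. Within the data shown here, the only measured step, no change at the digits printed from compound 1 to compound 2 (within the scatter), swapped cyclopentyl for isopropyl and involved neither an aromatic ring nor a hydrogen-bond donor, so it offers weak guidance. No step beyond the scatter is expected in this assay, with a wide margin. The expected step is a 1.4-fold lower number from compound 2 to compound 3 (0.15 log units; within the scatter). The estimate for compound 3 is 15000 nM, with an expected range of 5000 nM to 40000 nM.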

Compound 3, half-maximal inhibitory concentration: 21000 nM
The estimate for compound 3 lay 1.4-fold (0.15 log units) below the measured number, within the range that was stated.
By their numbers in this assay, from the lowest: compounds 1, 2 and 3 (each within the scatter of the next).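

In this assay, the carbonyl carbon now carries (4-chlorophenyl)amino, with one six-membered aromatic ring and one hydrogen-bond donor, and the data show no change at the digits printed from compound 2 to compound 3 (within the scatter) and no change at the digits printed from compound 1 to compound 3 (within the scatter). This position therefore accepts an aromatic ring and a hydrogen-bond donor, neither present in compound 1 or compound 2, with the read-out level at the digits printed. No measurement here accounts for this level read-out. Open, going by these compounds, is whether a carboxylic acid or a simple amine on this carbonyl carbon would leave this level, and whether phenylamino without its chlorine would hold it.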